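The source may report more compounds than this note shows. Statements on the series, on what has been measured and on what is new or still open speak of the compounds shown alone.

Working notes on the series. Compound 1 `N[C@H]1CC[C@H](Nc2c(C(=O)NCc3ccccn3)nc(Br)c3cccnc23)CC1` has no numerical result in a functional assay on SK-BR-3 cells (Homo sapiens) for cytotoxicity, read by MTT assay, with a stated time of 72 h; a higher number here means a weaker inhibitor, a lower number a stronger inhibitor: for compound 1 the entry reads "not determined" (no result reported), so it gives no anchor for comparison. Among the measured compounds shown here, compound 2 `N[C@H]1CC[C@H](Nc2c(C(=O)NCc3ccco3)nc(Br)c3cccnc23)CC1` is the only member with a numerical result: in this assay compound 2 gives 10000 nM, which is the sole number on record and therefore stands alone, with neither a stronger nor a weaker neighbour to place it against. The next member to be tested is compound 3 `N[C@H]1CC[C@H](Nc2c(C(=O)NCc3ccc(F)cc3)nc(Br)c3cccnc23)CC1`, which differs from compound 2 in one place: 4-fluorophenyl in place of furan-2-yl on a saturated chain carbon bound to an amide-type nitrogen. For the measured compounds named here, no step between two measured compounds is known, so the size of the effect has to be guessed from the change itself. A modest shift, if any, is expected, from compound 2 to compound 3 amounting to a 1.3-fold lower number from compound 2 to compound 3 (0.10 log units; within the scatter), with no strong case for either direction beyond the usual scatter. Compound 3 is accordingly estimated at 8000 nM, in a range from 3000 nM to 20000 nM.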

Compound 3, half-maximal inhibitory concentration: 2000 nM
Compound 3: middle estimate off by 4.0-fold (0.60 log units), on the high side, outside the stated range (below it).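

In this assay the change to 4-fluorophenyl in place of furan-2-yl gives a 5.0-fold lower number from compound 2 to compound 3 (0.70 log units; beyond the scatter). Among the compounds shown here, this is the first evidence that the group on a saturated chain carbon bound to an amide-type nitrogen affects the read-out, which the lone number for compound 2 could not show. No measurement shown accounts for the step, so it stands as an observation about this pair alone.

Steps involving compound 1 cannot be read, as it has no numerical result. The compounds shown leave open whether the lower number for compound 3 depends on the fluorine or on the six-membered carbon ring, and how a plain benzyl group, a 4-chlorobenzyl group or a longer chain such as 2-phenylethyl would compare in the same place.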